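The source may report more compounds than this note shows. Statements on the series, on what has been measured and on what is new or still open speak of the compounds shown alone.

Measured compounds:
- compound 1 `CN1CCN(c2nc(N)nc(COc3ccccc3)n2)CC1` gives 9530 nM in an assay on HEK293 cells for displacement of a labelled ligand from 5-hydroxytryptamine receptor 7 (Homo sapiens), read by radioligand binding, with a stated time of 1 h; on this read-out lower numbers stand for stronger inhibition and higher numbers for weaker inhibition
- compound 2 `CN1CCN(c2nc(N)nc(COc3ccccc3Cl)n2)CC1` gives 9250 nM in this assay

Compound 2 stands at the lower of the two numbers in this assay, but its nearest neighbour is compound 1, and the gap between them is within the scatter. Within the data shown here, the only measured step, a 1.0-fold lower number from compound 1 to compound 2 (0.01 log units; within the scatter), was therefore no real change.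

Compound 3 `Cc1ccc(OCc2nc(N)nc(N3CCN(C)CC3)n2)cc1` differs from compound 2 by 4-methylphenyl in place of 2-chlorophenyl on an oxygen on a saturated carbon. Among the measured compounds shown here, no measured step bears directly on this change: the one step recorded touches a different part of the shared core, and it was flat. For the measured compounds named here, there is thus no evidence on which to expect a shift in this assay in either direction beyond the scatter, and the numbers so far sit close together.

On that basis compound 3 is expected to give about 9500 nM, with a range from 4000 nM to 22000 nM, which amounts to an expected step of a 1.0-fold higher number from compound 2 to compound 3 (0.01 log units; within the scatter).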

Compound 3, inhibition constant: 16100 nM
Compound 3: the middle estimate sits 1.7-fold (0.23 log units) below what was measured; low and high end bracket the measured number.
By their numbers in this assay, from the lowest: compounds 2, 1 and 3 (each within the scatter of the next).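

In this assay, 4-methylphenyl in place of 2-chlorophenyl on an oxygen on a saturated carbon comes to a 1.7-fold higher number from compound 2 to compound 3 (0.24 log units; within the scatter) as the step, and a methyl group added to the aromatic ring comes to a 1.7-fold higher number from compound 1 to compound 3 (0.23 log units; within the scatter) as the step. The aromatic ring on that oxygen has now carried either a chloro or a methyl group, and all three compounds remain within the scatter of one another. Nothing given here explains these small steps.

The comparison of 2-chlorophenyl with 4-methylphenyl changes both the group and its place on the ring, so the two effects cannot be separated. Going by these compounds, whether an amine or a carboxylic acid on that ring, or a longer chain in place of the link to the oxygen, would move the number beyond the scatter remains open.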